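Cytotoxicity of a Pyrimidinyl Amide Predicted from Its Anilide

The source may report more compounds than this note shows. Statements on the series, on what has been measured and on what is new or still open speak of the compounds shown alone.

The series was profiled in a toxicity assay on HepG2 cells (Homo sapiens) for inhibition, read by CellTiter-Glo, with a stated time of 48 h; on this read-out higher numbers stand for weaker inhibition and lower numbers for stronger inhibition. Compound 1 `CCC(Oc1cc(C)nc2ccc(OC)cc12)C(=O)Nc1cc(C)cc(C)c1` gives 79400 nM in this assay. Compound 2 `COc1ccc2nc(C)cc(OCC(=O)Nc3c(C)cccc3C)c2c1` is a close relative built on the same core with a shorter link to the amide. In this assay compound 2 reaches only the limit of the measurement, > 100000 nM, so no number is known for it; the limit of > 100000 nM in this assay, at which 1 of the 2 values shown sits, describes that situation. Going by the values given here, compound 2 therefore stands at the weak end of what the two measured values show, with compound 1 the only compound given a number.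

Compound 3 `COc1ccc2nc(C)cc(OCC(=O)Nc3cc(C)nc(C)n3)c2c1` has not yet been measured. It differs from compound 2 in a single place: 2,6-dimethylpyrimidin-4-yl in place of 2,6-dimethylphenyl on an amide-type nitrogen. Among the compounds with values here, no pair of measured compounds differing in one place is available, so nothing measured speaks to the size of this change. The expected step of a number no higher from compound 2 to compound 3 (the limit leaves the size open) is none beyond the usual scatter, since compound 2 already sits at the limit > 100000 nM and weak inhibition is the likeliest outcome again. For compound 3 the estimate in this assay is 100000 nM, within a range from 40000 nM to 250000 nM.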

Compound 3, half-maximal inhibitory concentration: > 100000 nM
Compound 3: only a limit was reported; the forecaster's own chance of this, stated with the estimate: 70%; the middle value lies on the limit itself.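

In this assay compound 3 gives > 100000 nM, which is a limit of the assay and not a number. Going by these compounds alone, compound 2 also stands at a limit, so no step from compound 2 to compound 3 can be read: the limit of > 100000 nM in this assay, at which 2 of the 3 values shown sit. The compounds shown leave open whether 2,6-dimethylpyrimidin-4-yl in place of 2,6-dimethylphenyl on an amide-type nitrogen changes inhibition at all.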